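Amide-nitrogen aryl swaps in a quinoline ether series

A few compounds are considered here, and "the series" means these few. Any claim that something is new, unique, unknown or untested is made for them only; others in the source may bear on it.

Of the compounds shown here, three sharing one core have been measured in a physicochemical assay for solubility, in phosphate buffer, measured as kinetic solubility, with a stated time of 1 h, at pH 7.4; a higher number here means a more soluble compound, a lower number a less soluble compound. Compound 1 `COc1ccc2nc(C)cc(OCC(=O)Nc3cc(F)cc(F)c3)c2c1` gives 13000 nM. Compound 2 `COc1ccc2nc(C)cc(OCC(=O)Nc3ccc(Cl)cc3Cl)c2c1` gives 20500 nM, and compound 3 `COc1ccc2nc(C)cc(OCC(=O)Nc3ccc(Cl)c(OC)c3)c2c1` gives 13000 nM. Compound 3 is level with compound 1 at the digits shown, and the two together give the lowest of the three numbers; the step of no change at the digits printed from compound 1 to compound 3 (within the scatter) is within the scatter, as is a 1.6-fold lower number from compound 2 to compound 3 (0.20 log units; within the scatter) and a 1.6-fold higher number from compound 1 to compound 2 (0.20 log units; within the scatter). Among the compounds with values here, on the numbers so far, the three aryl groups on the amide-type nitrogen are not told apart in this assay.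

Compound 4 `COc1ccc2nc(C)cc(OCC(=O)Nc3nc(C)c(C)s3)c2c1` is not yet measured. It differs from compound 3 as follows: 4,5-dimethyl-1,3-thiazol-2-yl in place of 4-chloro-3-methoxyphenyl on an amide-type nitrogen. Within the data shown here, no measured step covers a swap of this kind; the steps available only exchange one six-membered carbon ring for another, and all fell within the scatter. Any expectation therefore rests on the narrow spread of the measured values, not on a directly comparable step. Compound 4 is expected to give 15000 nM, with a range of 6000 nM to 40000 nM, which means an expected step of a 1.2-fold higher number from compound 3 to compound 4 (0.06 log units; within the scatter), not beyond the scatter.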

Compound 4, solubility: 31500 nM
For compound 4 the middle estimate is 2.1-fold (0.32 log units) below the measured one; the range from low to high includes it.
By their numbers in this assay, from the lowest: compounds 1, 3, 2 and 4 (each within the scatter of the next, the first and the last beyond it).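

At the amide-type nitrogen, 4,5-dimethyl-1,3-thiazol-2-yl separates from two of the six-membered carbon rings in this assay (a 2.4-fold higher number from compound 3 to compound 4 (0.38 log units; beyond the scatter)) and (a 2.4-fold higher number from compound 1 to compound 4 (0.38 log units; beyond the scatter)), whereas the swaps among those rings gave no step beyond the scatter. Compound 2 goes against a clean split between the five-membered ring and the six-membered carbon rings, since its 2,4-dichlorophenyl group remains unresolved from the new group (a 1.5-fold higher number from compound 2 to compound 4 (0.19 log units; within the scatter)). Nothing available accounts for the steps to compound 4.

On these data alone, the thiazole ring and its two methyl groups enter as one change, so their separate contributions remain open. The 1,3-thiazol-2-yl group without those methyl groups, or one carrying an amine or a carboxylic acid, lies outside the compounds shown, leaving the reach of this position in this assay undefined.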